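The source may report more compounds than this note shows. Statements on the series, on what has been measured and on what is new or still open speak of the compounds shown alone.

- Compound 1 `Nc1ncnn2c([C@@H]3O[C@H](CO)[C@@H](O)[C@H]3O)cc(C#Cc3ccc(F)cc3)c12`: > 100000 nM, a limit
- Compound 2 `Nc1ncnn2c([C@@H]3O[C@H](CO)[C@@H](O)[C@H]3O)cc(C#Cc3cccs3)c12`: > 100000 nM, a limit
- Compound 3 `Nc1ncnn2c([C@@H]3O[C@H](CO)[C@@H](O)[C@H]3O)cc(-c3ccccc3)c12`: > 100000 nM, a limit

In a functional assay on K562 cells (Homo sapiens) for antiproliferative activity, with a stated time of 72 h (a higher number here means a weaker inhibitor, a lower number a stronger inhibitor), compound 2 gives > 100000 nM, which is a limit of the assay and not a number. Compound 4 `Nc1ncnn2c([C@@H]3O[C@H](CO)[C@@H](O)[C@H]3O)cc(-c3ccc(F)cc3F)c12` carries 2,4-difluorophenyl in place of 2-(thiophen-2-yl)ethynyl on an aromatic carbon.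

The closest measured change is a step that the two limits leave unreadable from compound 2 to compound 3, since it removes the same group and puts phenyl there. The other two, a step that the two limits leave unreadable from compound 1 to compound 3 and a step that the two limits leave unreadable from compound 1 to compound 2, add no size either. All the measurements rest at one ceiling: the limit of > 100000 nM in this assay, at which 3 of the 3 values shown sit. No step size can therefore be carried over to compound 4, and no direction can be read. The working expectation in this assay is no step beyond the scatter, and compound 4 may well be reported only as a limit too.

The expected change is a number no higher from compound 2 to compound 4 (the limit leaves the size open). The estimate for compound 4 is 100000 nM, with an expected range of 30000 nM to 200000 nM.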

Compound 4, half-maximal inhibitory concentration: 69700 nM
Compound 4: the middle estimate sits 1.4-fold (0.16 log units) above what was measured; low and high end bracket the measured number.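

In this assay compound 4 gives 69700 nM, so with 2,4-difluorophenyl on this aromatic carbon the shared core yields a real number rather than a limit, which the other compounds shown do not: the limit of > 100000 nM in this assay, at which 3 of the 4 values shown sit. Going by these compounds, the new result reads as an at least 1.4-fold lower number from compound 2 to compound 4 (0.15 log units; that floor lies within the scatter), as an at least 1.4-fold lower number from compound 3 to compound 4 (0.15 log units; that floor lies within the scatter) and as an at least 1.4-fold lower number from compound 1 to compound 4 (0.15 log units; that floor lies within the scatter), so each printed size is only a floor and the true size of these changes stays open. The steps among compounds 1, 2 and 3 cannot be read.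

On these data alone, it remains open whether a single fluorine on the phenyl ring would also lift the value off the limit. As far as these compounds go, it is also open how a methoxy group, an amine or a carboxylic acid on that ring would behave in this assay.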